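Chloro to Methoxy on the Aromatic Carbon: Expected Maximal Response

The source may report more compounds than this note shows. Statements on the series, on what has been measured and on what is new or still open speak of the compounds shown alone.

Three compounds have been measured in a functional assay on CHO cells for positive allosteric modulation of metabotropic glutamate receptor 2 (Homo sapiens), with a stated time of 30 min; a higher number here means a larger maximal response, a lower number a smaller maximal response:

compound 1, `N#Cc1c(N2CCC(c3ccccc3F)CC2)ccn(CC2CC2)c1=O`: 282%
compound 2, `N#Cc1c(N2CCC(c3cccc(F)c3)CC2)ccn(CC2CC2)c1=O`: 268%
compound 3, `N#Cc1c(N2CCC(c3ccccc3Cl)CC2)ccn(CC2CC2)c1=O`: 259%

Compound 3 carries the smallest of the three numbers, but the step of a number 9 percentage points lower from compound 2 to compound 3 (within the scatter) lies within the scatter, so compound 3 and compound 2 cannot be told apart. Only compound 1 stands clearly above it, with the step of a number 23 percentage points lower from compound 1 to compound 3 (beyond the scatter), and compound 1 also stands above compound 2 by a number 14 percentage points lower from compound 1 to compound 2 (beyond the scatter).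

Compound 4, `COc1ccccc1C1CCN(c2ccn(CC3CC3)c(=O)c2C#N)CC1`, has not yet been measured. Compared with compound 3 the difference is methoxy in place of chloro on an aromatic carbon.

Going by the values given here, only one measured step touches the same aromatic carbon: the change from fluoro to chloro, a number 23 percentage points lower from compound 1 to compound 3 (beyond the scatter), which was modest and downward. Among the compounds with values here, no measured pair involves a methoxy group, so there is no direct guide to its effect. A further modest move in either direction is possible, but a step of no more than the scatter seems the likeliest outcome, and the estimate for compound 4 is therefore 255% in this assay, within the range 215% to 295%. This estimate means an expected step of a number 4 percentage points lower from compound 3 to compound 4 (within the scatter).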

Compound 4, largest response reached (Emax), in percent of the reference or control that the assay uses: 265%
The estimate for compound 4 lay 10 percentage points below the measured number; the range from low to high includes it.
By their numbers in this assay, from the lowest: compounds 3, 4 and 2 (each within the scatter of the next); then compound 1.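

In this assay, methoxy, with two heavy atoms and one hydrogen-bond acceptor, can take the place of chloro, with one heavy atom and no acceptor, on this aromatic carbon ortho to a large group, and the two compounds cannot be told apart: a number 6 percentage points higher from compound 3 to compound 4 (within the scatter). Compound 4 also cannot be told apart from the 3-fluorophenyl compound, with a number 3 percentage points lower from compound 2 to compound 4 (within the scatter), whereas the 2-fluorophenyl compound stands clear of it, with a number 17 percentage points lower from compound 1 to compound 4 (beyond the scatter), just as it stands clear of the chloro compound, with a number 23 percentage points lower from compound 1 to compound 3 (beyond the scatter). So fluoro is the only one of the three groups on this carbon that separates from the others, and no measurement at hand offers an explanation for that.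

With only fluoro, chloro and methoxy shown on this carbon, it remains open whether a hydroxy group, an amino group or the longer ethoxy group would match the 2-fluorophenyl compound or fall in with compound 3 and compound 4. As far as these compounds go, it is also open whether methoxy on the 3-position of the phenyl ring would give a response that differs from that of compound 4, as the two fluoro compounds differ from each other.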